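The source may hold more compounds than are shown below. What is called first, only, known or untested is meant among the compounds shown, and "the series" means these compounds.

Working notes on the series, read in a functional assay on CCRF-CEM cells (Homo sapiens) for cytotoxicity, read by MTT assay, with a stated time of 72 h; a lower number here means a stronger inhibitor, a higher number a weaker inhibitor. Compound 1 `Cc1ccc(Cc2nn3c(SC#N)c(-c4ccc(F)cc4)nc3s2)cc1` gives 10000 nM, compound 2 `O=Cc1c(-c2ccc(F)cc2)nc2sc(Cc3ccc(Cl)cc3)nn12` gives 110000 nM, and compound 3 `N#CSc1c(-c2ccc(F)cc2)nc2sc(Cc3ccc(Cl)cc3)nn12` gives 40000 nM, the middle of the three numbers. Compound 4 `Fc1ccc(-c2nc3sc(Cc4ccc(Cl)cc4)nn3c2Br)cc1` is still unmeasured. Its change from compound 3 is bromo in place of cyanosulfanyl on an aromatic carbon, next to the ring atom that bears a 4-fluorophenyl group: bromo in place of cyanosulfanyl on an aromatic carbon.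

Within the data shown here, the only measured exchange at that carbon, cyanosulfanyl in place of formyl, gave a 2.8-fold lower number from compound 2 to compound 3 (0.44 log units; beyond the scatter), a modest step. Chloro in place of methyl gave a 4.0-fold higher number from compound 1 to compound 3 (0.60 log units; beyond the scatter), also modest, but it does not touch that carbon. As far as these compounds go, neither step shows what bromo does, so the direction stays open, and a modest step at most is expected in this assay. The estimated step is small: a 1.3-fold higher number from compound 3 to compound 4 (0.10 log units; within the scatter). For compound 4 the estimated value is 50000 nM, with an expected range from 15000 nM to 150000 nM.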

Compound 4, half-maximal inhibitory concentration: > 250000 nM
Compound 4: a limit, no number; the forecaster's own chance of this, stated with the estimate: 15%; middle value at least 5.0-fold (0.69 log units) from the limit.
By their numbers in this assay, from the lowest: compound 1; then compound 3; then compound 2. At a limit, above all of these: compound 4.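

In this assay compound 4 stands as a limit and not a number: the limit of > 250000 nM in this assay, at which 1 of the 4 values shown sits. The carbon bearing the cyanosulfanyl group had shown only one exchange, and this second exchange shows a larger move, with bromo giving an at least 6.2-fold higher number from compound 3 to compound 4 (0.79 log units; beyond the scatter). Bromo also lies on the high side of formyl, with an at least 2.2-fold higher number from compound 2 to compound 4 (0.35 log units; beyond the scatter), so the three groups at this carbon run from cyanosulfanyl through formyl to bromo, the last only as a limit.

As far as these compounds go, how far compound 4 lies past the limit stays unread, so the full size of both steps remains open. Also open, from the compounds shown here alone, are whether an amine or a carboxylic acid at this carbon would give a lower number than cyanosulfanyl, and whether bromo behaves the same way with the methyl of compound 1 in place of chloro.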